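The compounds below may be only part of what the source reports. "The series", "measured", "known", "first", "only" and "open" are said of these compounds alone.

Working notes on the series. Compound 1 `O=C1CSC(=O)N1C[C@H]1CN(c2ccc(-n3cc(-c4ccccn4)cn3)c(F)c2)C(=O)O1` carries a (2,4-dioxo-1,3-thiazolidin-3-yl)methyl group on the shared core; in a physicochemical assay for lipophilicity, read by HPLC, measured as octanol-water partition (a higher number here means a more lipophilic compound, a lower number a more polar compound), compound 1 gives 2.18. Compound 2 `COC[C@H]1CN(c2ccc(-n3cc(-c4ccccn4)cn3)c(F)c2)C(=O)O1` is the closest measured neighbour, and in this assay compound 2 gives 2.18. Among the compounds with values here, the one measured step, no change at the digits printed from compound 1 to compound 2 (within the scatter), exchanges methoxy for the five-membered group on the saturated chain carbon and leaves the read-out where it was. On the numbers shown, compound 1 therefore stands level with compound 2, with nothing to separate them beyond the scatter.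

The next compound is compound 3 `CONC(=O)[C@H]1CN(c2ccc(-n3cc(-c4ccccn4)cn3)c(F)c2)C(=O)O1`, which differs from compound 1 as follows: methoxycarbamoyl in place of (2,4-dioxo-1,3-thiazolidin-3-yl)methyl on a saturated ring carbon. This change removes the chain carbon together with the five-membered group and puts a methoxycarbamoyl group directly on the ring carbon, so neither of the measured compounds matches it closely. Within the data shown here, the only step that bears on it is no change at the digits printed from compound 1 to compound 2 (within the scatter), which was flat, but it did not introduce a hydrogen-bond donor, whereas the incoming group does. A modest downward step is expected, a number 0.48 log units lower from compound 1 to compound 3 (beyond the scatter), and compound 3 is estimated at 1.7, within 1.2 to 2.3.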

Compound 3, partition coefficient: >= 1.58
Compound 3: only a limit was reported; the forecaster's own chance of this, stated with the estimate: 2%; the middle value is on the limit's open side.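

In this assay compound 3 is reported only as a limit, >= 1.58. Within the data shown here, the steps from compound 1 and from compound 2 to compound 3 cannot be read, so no new step comes from this result. The compounds shown leave open where compound 3 stands relative to compound 1 and compound 2.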